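The compounds below may be only part of what the source reports. "The series", "measured", "known", "first", "only" and "open" are said of these compounds alone.

Of the compounds shown here, two with a shared core have been tested in an assay for inhibition of kynurenine 3-monooxygenase (Homo sapiens), read by mass spectrometry, with a stated time of 1 h; on this read-out higher numbers stand for weaker inhibition and lower numbers for stronger inhibition. Compound 1, `Cc1ccc([C@@H](C)Oc2cc3oc(=O)n(CCC(=O)O)c3cc2Cl)nc1`, gives in this assay 3.16 nM. Compound 2, `O=C(O)CCn1c(=O)oc2cc(OCc3ccccn3)c(Cl)cc21`, gives in this assay 3.16 nM. On these numbers compound 2 stands level with compound 1: the two values agree at the digits shown, and the gap between them lies within the scatter of repeated measurements, so no order can be read from them.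

Compound 3, `CCOc1cc2oc(=O)n(CCC(=O)O)c2cc1Cl`, has not yet been measured. It differs from compound 2 by methyl in place of pyridin-2-yl on a saturated chain carbon bound to an oxygen on an aromatic ring. Compound 1 and compound 2 each carry a six-membered aromatic ring at this place, and both reach the same potency; compound 3 keeps only a methyl there. Among the measured compounds shown here, with no measured step to lean on, a loss of potency of moderate size is expected, a 7.9-fold higher number from compound 2 to compound 3 (0.90 log units; beyond the scatter), beyond the usual scatter. Compound 3 is therefore estimated at 25 nM, with a range from 5 nM to 150 nM.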

Compound 3, half-maximal inhibitory concentration: 5.01 nM
The estimate for compound 3 lay 5.0-fold (0.70 log units) above the measured number; the range from low to high includes it.
By their numbers in this assay, from the lowest: compounds 1, 2 and 3 (each within the scatter of the next).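

In this assay the numbers show a 1.6-fold higher number from compound 2 to compound 3 (0.20 log units; within the scatter) on going from (pyridin-2-yl)methoxy to ethoxy, so at this place the six-membered aromatic ring is not required for a value in the range of compound 2. The wider difference, hydrogen in place of 5-methylpyridin-2-yl, reads as a 1.6-fold higher number from compound 1 to compound 3 (0.20 log units; within the scatter) and likewise gives no order among these compounds. Nothing available explains why these values stay so close.

The compounds shown leave open how far this tolerance extends, since a longer chain such as propoxy, a phenyl ring in place of pyridin-2-yl, or an amine at the end of the chain could each read differently. They also leave open whether a bare hydroxyl at this place would keep a similar value.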